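The compounds below may be only part of what the source reports. "The series", "measured", "known", "first", "only" and "open" are said of these compounds alone.

Compound 1 `Cn1cncc1C(CC(=O)O)c1ccc(OCC2COc3ccc(Cl)cc3O2)cc1`: 62%
Compound 2 `CC#C[C@@H](CC(=O)O)c1ccc(OC[C@@H]2COc3ccc(Cl)cc3O2)cc1`: 65%
Compound 3 `CC#C[C@@H](CC(=O)O)c1ccc(OC[C@H]2COc3ccc(Br)cc3O2)cc1`: 69%

The three compounds were measured in a functional assay on HEK293 cells for agonist activity at Free fatty acid receptor 1 (Homo sapiens), read by fluorescence and calcium flux, with a stated time of 10 min; on this read-out lower numbers stand for smaller maximal responses and higher numbers for larger maximal responses. Compound 1 gives 62%, compound 2 gives 65%, and compound 3 gives 69%. Compound 3 carries the highest of the three numbers, but its nearest neighbour, compound 2, lies within the usual scatter of this kind of measurement, and so does the furthest of the three, compound 1. The three values therefore cannot be told apart with confidence, and no ordering among them is claimed.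

Compound 4 `CC#C[C@@H](CC(=O)O)c1ccc(OC[C@H]2COc3ccc(OC(C)C)cc3O2)cc1` has not yet been measured in this assay. Compared with compound 3 it differs in one place: isopropoxy in place of bromo on an aromatic carbon. Among the measured compounds shown here, there is no measured pair in this set that shows what such an exchange does, so the expectation for compound 4 rests only on how little the three measured values move among themselves. The step of a number 4 percentage points lower from compound 3 to compound 4 (within the scatter) is expected to be small, likely none beyond the scatter, in either direction. Compound 4 is accordingly expected to give about 65% in this assay, with a range from 50% to 80%.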

Compound 4, largest response reached (Emax), in percent of the reference or control that the assay uses: 90%
Compound 4: middle estimate off by 25 percentage points, on the low side, and the stated range ends below it.
By their numbers in this assay, from the lowest: compounds 1, 2 and 3 (each within the scatter of the next); then compound 4.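

In this assay, among the compounds shown here, isopropoxy in place of bromo on this aromatic carbon of the shared core gives a number 21 percentage points higher from compound 3 to compound 4 (beyond the scatter), the only step in the set that is printed as beyond the scatter. The earlier compounds shown here sat within the scatter of one another and offered no matched pair, so they could not show that this position matters; this pair shows that the group on this carbon can change the largest response reached, with compound 4 now standing apart from compounds 1, 2 and 3. The exchange replaces one bromine atom with four heavy atoms, three carbon and one oxygen, and adds one hydrogen-bond acceptor, but no measurement here bears on why the response rises.

The compounds shown leave open whether the rise goes with the oxygen attached to the ring or with the branched carbon part of the isopropoxy group. They also leave open what a methoxy group, a longer chain such as butoxy, or an amine would do on this same aromatic carbon.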